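Naphthalen-1-yl replaces thiophen-3-yl on the acetal carbon

The compounds below may be only part of what the source reports. "The series", "measured", "known", "first", "only" and "open" are said of these compounds alone.

Measured compounds:
compound 1, `O=C(O)CC/C=C\CC1COC(c2ccc(C(F)(F)F)cc2)OC1c1cccnc1`, 44 nM
compound 2, `O=C(O)CC/C=C\CC1COC(c2ccsc2)OC1c1cccnc1`, 500 nM

Of the compounds shown here, two share a core and have been measured in an assay for inhibition of Thromboxane-A synthase (Homo sapiens), using microsomes; a higher number here means a weaker inhibitor, a lower number a stronger inhibitor. Compound 1 gives 44 nM in this assay, and compound 2 gives 500 nM. For the measured compounds named here, of the two numbers, compound 2 stands highest: the only step known, an 11-fold higher number from compound 1 to compound 2 (1.06 log units; beyond the scatter), places it well beyond the scatter from compound 1.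

Compound 3, `O=C(O)CC/C=C\CC1COC(c2cccc3ccccc23)OC1c1cccnc1`, has not yet been measured. It differs from compound 2 in one place: naphthalen-1-yl in place of thiophen-3-yl on a saturated ring carbon. Going by the values given here, the one measured step that bears on this change is the step from compound 1 to compound 2, where a group with two six-membered rings of carbon only gives way to a five-membered ring with one hetero atom, and the number rises by an 11-fold higher number from compound 1 to compound 2 (1.06 log units; beyond the scatter). Compound 3 reverses that direction, so a lower number than for compound 2 is expected, though the group entering is not the one that left in the earlier step. The step from compound 2 to compound 3 is estimated at a 5.0-fold lower number from compound 2 to compound 3 (0.70 log units; beyond the scatter). Compound 3 is therefore expected to give about 100 nM in this assay, within a range of 30 nM to 400 nM.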

Compound 3, half-maximal inhibitory concentration: 40 nM
Compound 3: the middle estimate sits 2.5-fold (0.40 log units) above what was measured; the measured number falls inside the stated range.
By their numbers in this assay, from the lowest: compounds 3 and 1 (each within the scatter of the next); then compound 2.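

In this assay, the saturated ring carbon between two ring oxygen atoms now shows a second large step, a 13-fold lower number from compound 2 to compound 3 (1.10 log units; beyond the scatter), with naphthalen-1-yl in place of thiophen-3-yl. The step of a 1.1-fold lower number from compound 1 to compound 3 (0.04 log units; within the scatter) lies within the scatter, so naphthalen-1-yl and 4-(trifluoromethyl)phenyl cannot be told apart at this position, and compound 2, with the only five-membered ring with a hetero atom among the three, is the one that stands apart from both others. Nothing given here explains why these groups differ in this way.

The three compounds do not separate the effect of ring size, the sulfur atom and the second aromatic ring, and an unsubstituted phenyl, a naphthalen-2-yl or a furan-3-yl group on the same carbon would be needed to pull these apart. From the compounds shown here alone, it also remains open whether the same ranking of groups on this carbon would hold if the 5-carboxypent-2-en-1-yl group gave way to a shorter chain or the pyridin-3-yl group to a plain phenyl.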